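A few compounds are considered here, and "the series" means these few. Any claim that something is new, unique, unknown or untested is made for them only; others in the source may bear on it.

In a functional assay on MDA-MB-231 cells (Homo sapiens) for antiproliferative activity, read by sulforhodamine B assay, with a stated time of 72 h (a lower number here means a stronger inhibitor, a higher number a weaker inhibitor), compound 1 `COc1cccc(/C=C2\CCC=CC2=O)c1` gives 1060 nM while compound 2 `COc1cc(/C=C2\CCC=CC2=O)cc(OC)c1` gives 600 nM and compound 3 `COc1cc(OC)c(/C=C2\CCC=CC2=O)c(OC)c1` gives 5070 nM on the same scale. Compound 2 therefore sits at the low end of these numbers, level with compound 1 within the scatter and well under compound 3. Compound 4 `COc1cc(/C=C2\CCC=CC2=O)cc(OC)c1O` carries one change from compound 2, namely hydroxy in place of hydrogen on an aromatic carbon. Going by the values given here, the only measured single change, methoxy in place of hydrogen on an aromatic carbon, is a 1.8-fold lower number from compound 1 to compound 2 (0.25 log units; within the scatter) and so a similarly small shift in this assay is expected. The expected step is a 1.3-fold higher number from compound 2 to compound 4 (0.10 log units; within the scatter) on this reasoning. For compound 4 the estimated value is 750 nM with an expected range of 250 nM to 2200 nM for now.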

Compound 4, half-maximal inhibitory concentration: 1610 nM
Compound 4: middle estimate off by 2.1-fold (0.33 log units), on the low side; the measured number falls inside the stated range.
By their numbers in this assay, from the lowest: compounds 2, 1 and 4 (each within the scatter of the next, the first and the last beyond it); then compound 3.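

Putting hydroxy in place of hydrogen on the aromatic carbon ortho to two methoxy groups gives a 2.7-fold higher number from compound 2 to compound 4 (0.43 log units; beyond the scatter) in this assay. Going by these compounds alone, this is the first single change here to reach beyond the scatter, as the methoxy step a 1.8-fold lower number from compound 1 to compound 2 (0.25 log units; within the scatter) stayed within it, so a change at this position can move the number upward. Nothing available explains this rise.

As far as these compounds go, what a methoxy group, an amine or a fluorine atom on this same carbon would do remains open. The compounds shown therefore cannot tell whether the step is particular to hydroxy.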